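This account rests on a few compounds, and the source may have more. Where it says the series, first, only, none or still open, it means among the compounds named here.

Compounds measured in a functional assay on the whole organism for antagonist activity, with Mus musculus as the target; on this read-out lower numbers stand for an effect already at smaller amounts and higher numbers for an effect only at larger amounts of compound:
- compound 1 `CCCCCC(=O)NCC(=O)N(C)c1ccc(Cl)cc1C(=O)c1ccccc1Cl`: 1.9 mg/kg
- compound 2 `CC(C)NCC(=O)NCC(=O)N(C)c1ccc(Cl)cc1C(=O)c1ccccc1Cl`: 1 mg/kg
- compound 3 `CCCCCCC(=O)NCC(=O)N(C)c1ccc(Cl)cc1C(=O)c1ccccc1Cl`: 1.9 mg/kg

Compound 2 cannot be separated from the other two measured compounds. The numbers show a 1.9-fold lower number from compound 1 to compound 2 (0.28 log units; within the scatter) and a 1.9-fold higher number from compound 2 to compound 3 (0.28 log units; within the scatter), so all three stand level within the scatter.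

Still unmeasured is compound 4 `CC(C)C(=O)NCC(=O)N(C)c1ccc(Cl)cc1C(=O)c1ccccc1Cl`. The change from the reference compound is isopropyl in place of (isopropylamino)methyl on a carbonyl carbon. In words, isopropyl stands in place of (isopropylamino)methyl on a carbonyl carbon, so the isopropylamino group is lost.

The same two steps bear most directly on this change, since each exchanges isopropylamino with a plain alkyl group, butyl or pentyl, on a saturated chain carbon bound to a carbonyl carbon. Neither exchange leaves the scatter. The third measured step, no change at the digits printed from compound 1 to compound 3 (within the scatter), shows no difference from lengthening the plain chain. Among the measured compounds shown here, no measured compound carries a chain as short as isopropyl on this carbonyl carbon, so the expectation is an extrapolation and the range is kept wide.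

The expected size is a 1.9-fold higher number from compound 2 to compound 4 (0.28 log units; within the scatter), a small step towards a higher number that is not expected to clear the scatter. For compound 4 the estimated value is 1.9 mg/kg, with an expected range from 0.8 mg/kg to 5 mg/kg.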

Compound 4, dose for half-maximal effect: 6 mg/kg
Compound 4: middle estimate off by 3.2-fold (0.50 log units), on the low side; measured number above the stated range.
By their numbers in this assay, from the lowest: compounds 2, 1 and 3 (each within the scatter of the next); then compound 4.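

Working notes on the carbonyl carbon position: in this assay, (isopropylamino)methyl, pentyl and hexyl stood level within the scatter, and isopropyl is the first group here to leave it, with a 6.0-fold higher number from compound 2 to compound 4 (0.78 log units; beyond the scatter) and, against the plain chains, a 3.2-fold higher number from compound 1 to compound 4 (0.50 log units; beyond the scatter) and a 3.2-fold higher number from compound 3 to compound 4 (0.50 log units; beyond the scatter). Loss of the isopropylamino group alone does not account for the higher number of compound 4, since compound 1 and compound 3 also lack that group and remain level with compound 2; the change that separates compound 4 from those two plain-chain compounds is the replacement of pentyl or hexyl by isopropyl. Nothing at hand explains why this group gives the higher number.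

The compounds shown leave open whether the shift follows the shorter chain or its branching, a question that straight-chain propyl and butyl groups on the same carbonyl carbon would help to separate. Also open, on these data alone, is how far the isopropylamino group can be varied, for example by a primary amine or a carboxylic acid in its place.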